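Ester-chain variants of one core in liver microsomes

This account rests on a few compounds, and the source may have more. Where it says the series, first, only, none or still open, it means among the compounds named here.

All four compounds share the core of compound 1 `CCOC(=O)/C=C/c1ccc(NC(=O)C2(NC(=O)c3ccc4c(C5CCCC5)c(-c5ncc(Cl)cn5)n(C)c4c3)CCC2)cc1OCC` and differ only at the ester end of the chain. Compound 2 `CCCCCCOC(=O)/C=C/c1ccc(NC(=O)C2(NC(=O)c3ccc4c(C5CCCC5)c(-c5ncc(Cl)cn5)n(C)c4c3)CCC2)cc1OCC` and compound 3 `CCOc1cc(NC(=O)C2(NC(=O)c3ccc4c(C5CCCC5)c(-c5ncc(Cl)cn5)n(C)c4c3)CCC2)ccc1/C=C/C(=O)OCCOc1ccccc1` are the measured variants, compound 4 `CCOc1cc(NC(=O)C2(NC(=O)c3ccc4c(C5CCCC5)c(-c5ncc(Cl)cn5)n(C)c4c3)CCC2)ccc1/C=C/C(=O)OCCOCCOC` the unmeasured one.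

In an ADME assay (liver) for pharmacokinetics, with Liver microsome (Homo sapiens) as the target, using microsomes (a higher number here means that the compound lasts longer, a lower number that the compound disappears faster), compound 2 gives 17.9 h. For compound 1 this assay reports only a limit, > 5 h. For compound 3 this assay likewise reports only a limit, > 5 h. Compound 3 thus stands at the limit of > 5 h in this assay, at which 2 of the 3 values shown sit, not at a number.

The measured steps are a step that the limit leaves unreadable from compound 1 to compound 2, a step that the two limits leave unreadable from compound 1 to compound 3 and a step that the limit leaves unreadable from compound 2 to compound 3; none of them has a readable size, so no direction can be taken from them.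

The change to compound 4 is 2-methoxyethyl in place of phenyl on an oxygen on a saturated carbon. On these data the step from compound 3 to compound 4 is expected to be a step that the limit leaves unreadable from compound 3 to compound 4, nothing beyond the scatter. Compound 4 is therefore estimated at 10 h, with a range from 3.5 h to 30 h, and this assay may again report only a limit.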

Compound 4, half-life: 0.85 h
Estimate against measurement, compound 4: 12-fold (1.07 log units) above; the measured number lies below the stated range.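

In this assay, the ester end of the chain gives its first readable steps: an at least 5.8-fold lower number from compound 3 to compound 4 (0.76 log units; beyond the scatter), and an at least 5.8-fold lower number from compound 1 to compound 4 (0.76 log units; beyond the scatter). The largest step is a 21-fold lower number from compound 2 to compound 4 (1.32 log units; beyond the scatter), so this chain position is not indifferent to what it carries, and 2-methoxyethoxy in place of butyl shortens the half-life well beyond the scatter. The steps among compound 1, compound 2 and compound 3 cannot be read, and the true size of the steps from compound 1 and compound 3 stays bounded only: the limit of > 5 h in this assay, at which 2 of the 4 values shown sit.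

As far as these compounds go, with one compound carrying 2-methoxyethoxy, it stays open whether the lower half-life goes with the oxygen in that chain or with the chain as a whole. From the compounds shown here alone, what a carboxylic acid, an amine or a longer chain of the same kind would give at this end also stays open.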